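The source may report more compounds than this note shows. Statements on the series, on what has been measured and on what is new or still open speak of the compounds shown alone.

Series values in a functional assay on RKO cells (Homo sapiens) for cytotoxicity, read by resazurin assay, with a stated time of 72 h; a lower number here means a stronger inhibitor, a higher number a weaker inhibitor:
- compound 1 `COc1cccc(Nc2nc(-n3cc(C)nc3C)cs2)c1`: 22500 nM
- compound 2 `Cc1nc2ccccc2n1-c1csc(Nc2ccc(Br)cc2)n1`: 90 nM
- compound 3 `COc1ccc(Nc2nc(-n3c(C)nc4ccccc43)cs2)cc1`: 25 nM

Compound 1 holds the highest of the three numbers, far above compound 2 at 90 nM and compound 3 at 25 nM. Compound 4 `Cc1cn(-c2csc(Nc3cccc(Br)c3)n2)c(C)n1` has bromo in place of methoxy on an aromatic carbon relative to compound 1: bromo in place of methoxy on an aromatic carbon.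

Within the data shown here, one measured step bears on this change, and it runs the opposite way on a different core: a 3.6-fold lower number from compound 2 to compound 3 (0.56 log units; beyond the scatter). Read in reverse, it suggests a modest rise in this assay, though its transfer to this core is untested. Little change, at most a modest rise, is therefore expected. The expected step is a 1.3-fold higher number from compound 1 to compound 4 (0.12 log units; within the scatter). Compound 4 is estimated at 30000 nM, with an expected range of 8000 nM to 90000 nM.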

Compound 4, half-maximal inhibitory concentration: > 100000 nM
Compound 4 gave a limit, no number; the forecaster's own chance of this, stated with the estimate: 20%; middle value at least 3.3-fold (0.52 log units) away from the limit.
By their numbers in this assay, from the lowest: compound 3; then compound 2; then compound 1. At a limit, above all of these: compound 4.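

In this assay, bromo in place of methoxy, meta to a large group, gives an at least 4.4-fold higher number from compound 1 to compound 4 (0.64 log units; beyond the scatter) on the core of compound 1. Compound 4 stands at > 100000 nM as a limit, not a number. The change now points the same way on two cores, with methoxy holding the lower number on both: the same change on two cores in this assay, a 3.6-fold lower number (0.56 log units; beyond the scatter) from compound 2 to compound 3 and an at least 4.4-fold lower number (0.64 log units; beyond the scatter) from compound 4 to compound 1; the limit leaves it open whether they differ.

Going by these compounds, the true size of the step to compound 4 stays open. So does how an amine or a carboxylic acid at this place would read in this assay on either core.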